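Branching Swap at the Alpha Carbon of Compound 3

This account rests on a few compounds, and the source may have more. Where it says the series, first, only, none or still open, it means among the compounds named here.

Compound 3 `CC(=O)c1ccc(NC(=O)C(CC(C)C)N(C(=O)c2ccccc2)S(=O)(=O)c2ccccc2)cc1` gives 3200000 nM in a functional assay, read by spectrophotometry, with a stated time of 20 min (on this read-out higher numbers stand for weaker inhibition and lower numbers for stronger inhibition), the lowest of the three numbers shown. Compound 1 `CCC(C)C(C(=O)Nc1ccc(C(C)=O)cc1)N(C(=O)c1ccccc1)S(=O)(=O)c1ccc(C)cc1` gives 10000000 nM, and compound 2 `CC(=O)c1ccc(NC(=O)CN(C(=O)c2ccccc2)S(=O)(=O)c2ccccc2)cc1` gives 32000000 nM. Going by the values given here, the only measured step touching this side chain is a 10-fold lower number from compound 2 to compound 3 (1.00 log units; beyond the scatter), which shows that a branched chain at that carbon matters. Compound 4 `CCC(C)C(C(=O)Nc1ccc(C(C)=O)cc1)N(C(=O)c1ccccc1)S(=O)(=O)c1ccccc1` differs from compound 3 by sec-butyl in place of isobutyl on a saturated chain carbon bound to an amide-type nitrogen and a carbonyl carbon. Among the compounds with values here, no measured pair isolates this swap; compound 1 also carries sec-butyl but differs from compound 4 elsewhere, and its value lies above that of compound 3. Compound 4 is therefore expected to show a modest rise, a 1.8-fold higher number from compound 3 to compound 4 (0.24 log units; within the scatter), at the edge of the scatter. The estimate for compound 4 is 5600000 nM, ranging from 1800000 nM to 18000000 nM.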

Compound 4, half-maximal inhibitory concentration: 8600000 nM
The estimate for compound 4 lay 1.5-fold (0.19 log units) below the measured number, within the range that was stated.
By their numbers in this assay, from the lowest: compound 3; then compounds 4 and 1 (each within the scatter of the next); then compound 2.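

In this assay, the place of the branch within the side chain counts on its own: sec-butyl in place of isobutyl gives (a 2.7-fold higher number from compound 3 to compound 4 (0.43 log units; beyond the scatter)), although compound 3 and compound 4 have the same atoms. Sec-butyl still keeps a gain over hydrogen at this carbon (a 3.7-fold lower number from compound 2 to compound 4 (0.57 log units; beyond the scatter)). Methyl on an aromatic carbon, by contrast, makes no difference beyond the scatter (a 1.2-fold lower number from compound 1 to compound 4 (0.07 log units; within the scatter)).

Going by these compounds, whether a longer chain, a benzyl group or a carboxylic acid at this carbon would give a lower number than isobutyl stays open. Nothing available explains why the two chains differ.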